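Aryloxypentyl series: cytotoxicity before the bromophenyl analogue

This account rests on a few compounds, and the source may have more. Where it says the series, first, only, none or still open, it means among the compounds named here.

Three aryloxypentyl analogues of the shared core have been tested in an ADME assay on HEL cells (Homo sapiens) for cytotoxicity; on this read-out lower numbers stand for higher toxicity in this test and higher numbers for lower toxicity in this test. Compound 1 `Cc1cccc(OCCCCCn2ccc(=O)[nH]c2=O)c1` returns only a limit in this assay, > 100000 nM. Compound 2 `N#Cc1ccc(OCCCCCn2ccc(=O)[nH]c2=O)cc1` gives 100000 nM in this assay. Compound 3 `CCCOC(=O)c1ccc(OCCCCCn2ccc(=O)[nH]c2=O)cc1` likewise reaches only a limit, > 100000 nM. Among the measured compounds shown here, the single step that can be read, a number no lower from compound 2 to compound 3 (the limit leaves the size open), leaves its size open, and the limit of > 100000 nM in this assay, at which 2 of the 3 values shown sit, marks where most of the set sits. Compound 1 therefore stands at the edge of what this assay resolves, with no number beneath it; none of the three compounds shows cytotoxicity inside the tested range.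

Compound 4 `O=c1ccn(CCCCCOc2ccc(Br)cc2)c(=O)[nH]1` is still to be measured in this assay. Against compound 1 the change is 4-bromophenyl in place of 3-methylphenyl on an oxygen on a saturated carbon. For the measured compounds named here, no measured step matches this change directly; the only measured step replaces one aryl substituent by another and shows no readable size, the read-out staying at the limit. Compound 4 is therefore expected to stay at the limit as well, with an estimated step of a number no higher from compound 1 to compound 4 (the limit leaves the size open) that does not reach beyond the scatter. The estimate for compound 4 is 100000 nM, within 50000 nM and 200000 nM.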

Compound 4, half-maximal cytotoxic concentration: > 100000 nM
Compound 4 gave a limit, no number; the forecaster's own chance of this, stated with the estimate: 70%; the middle value sits exactly at the limit.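

Among the compounds shown here, the 4-bromophenyl group is the first halogen-bearing aryl group, and it leaves the read-out in this assay at a limit: compound 4 gives > 100000 nM, which is a limit and not a number. Bromo in place of cyano on an aromatic carbon gives a number no lower from compound 2 to compound 4 (the limit leaves the size open), so bromo now joins cyano and propoxycarbonyl as substituents at this place with no read-out lower than that of compound 2. The steps from compound 1 and from compound 3 to compound 4 cannot be read, since both ends are limits, and the series now gathers at one edge of this assay: the limit of > 100000 nM in this assay, at which 3 of the 4 values shown sit.

Going by these compounds, how far these compounds lie from one another beyond that limit remains open, so no order among them can be drawn. Also open, on these data alone, is whether an amine or a carboxylic acid on the aromatic ring, or a longer chain in place of the pentyl chain, would bring the read-out to a number under the limit.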